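The source may report more compounds than this note shows. Statements on the series, on what has been measured and on what is new or still open speak of the compounds shown alone.

Measured compounds:
- compound 1 `O=S(=O)(NCCNc1nccc(-c2c(-c3cccc(F)c3)nc3sccn23)n1)c1ccc(F)cc1` gives 9450 nM in a functional assay on SK-MEL-28 cells (Homo sapiens) for cytotoxicity, read by MTT assay; a higher number here means a weaker inhibitor, a lower number a stronger inhibitor
- compound 2 `O=S(=O)(NCCCNc1nccc(-c2c(-c3cccc(F)c3)nc3sccn23)n1)c1ccccc1` gives 6850 nM in this assay

Within the data shown here, compound 2 holds the lowest of the two numbers in this assay, but its only neighbour is compound 1, and the step of a 1.4-fold lower number from compound 1 to compound 2 (0.14 log units; within the scatter) is within the scatter, so the two compounds cannot be set apart on these numbers.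

Compound 3 `Cc1ccc(C(=O)NCCNc2nccc(-c3c(-c4cccc(F)c4)nc4sccn34)n2)cc1` differs from compound 2 in one place: ((4-methylphenyl)carbonyl)amino in place of ((phenylsulfonyl)amino)methyl on a saturated chain carbon, two bonds along the chain from a nitrogen on an aromatic ring. The sulfonamide is thus exchanged for an amide carrying a methyl on its ring, and the linking chain becomes one atom shorter.

Among the measured compounds shown here, only one measured step bears on this region of the molecule, the change at the same chain position from compound 1 to compound 2, and that step, a 1.4-fold lower number from compound 1 to compound 2 (0.14 log units; within the scatter), did not exceed the scatter. Nothing measured speaks to the sulfonamide-to-amide exchange itself, so no direction can be read from the data. Compound 3 is therefore expected to sit close to compound 2, with a step of a 1.0-fold higher number from compound 2 to compound 3 (0.01 log units; within the scatter) in this assay, and an estimate of 7000 nM within the range 2500 nM to 20000 nM.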

Compound 3, half-maximal inhibitory concentration: 18800 nM
Compound 3: middle estimate off by 2.7-fold (0.43 log units), on the low side; the measured number falls inside the stated range.
By their numbers in this assay, from the lowest: compounds 2, 1 and 3 (each within the scatter of the next, the first and the last beyond it).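

In this assay, among these compounds, ((4-methylphenyl)carbonyl)amino in place of ((phenylsulfonyl)amino)methyl gives a 2.7-fold higher number from compound 2 to compound 3 (0.44 log units; beyond the scatter) and so provides the first step at this chain position to pass beyond the scatter, showing that the number can respond to a change at this place, though only modestly. With the chain length held, (4-methylphenyl)carbonyl in place of (4-fluorophenyl)sulfonyl on an amine nitrogen gives a 2.0-fold higher number from compound 1 to compound 3 (0.30 log units; within the scatter) and does not separate the two compounds, so the carbonyl-for-sulfonyl exchange alone has not been shown to shift the number in this assay. No supporting evidence is available to explain the result.

The step beyond the scatter combines a shorter chain, a carbonyl in place of a sulfonyl and a methyl on the ring, so the compounds shown cannot say which of these changes matters, and the same (4-methylphenyl)carbonyl amide on the longer chain of compound 2 would be needed to separate them. On these data alone, it also remains open whether a urea, a tertiary amine or a carboxylic acid at the end of the chain would bring the number below that of compound 2.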